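Swapping the Amide Substituent in a Sulfonamide Series

The source may report more compounds than this note shows. Statements on the series, on what has been measured and on what is new or still open speak of the compounds shown alone.

Compound 1 `CN(C)c1ccc(C(=O)N2CCC(NS(=O)(=O)c3cc(S(=O)(=O)c4ccccc4)ccc3C(F)(F)F)CC2)cn1` gives the lower of the two numbers measured in an assay on isolated protein for displacement of a labelled ligand from secreted frizzled-related protein 1 (Homo sapiens), read by fluorescence polarization, with a stated time of 30 min (on this read-out higher numbers stand for weaker inhibition and lower numbers for stronger inhibition), where compound 1 gives 40 nM. Compound 2 `CC(C)(C)OC(=O)N1CCC(C(=O)N2CCC(NS(=O)(=O)c3cc(S(=O)(=O)c4ccccc4)ccc3C(F)(F)F)CC2)CC1` in this assay gives 300 nM, a gap that lies beyond the scatter of the method. Compound 3 `O=C([C@H]1CCNC1)N1CCC(NS(=O)(=O)c2cc(S(=O)(=O)c3ccccc3)ccc2C(F)(F)F)CC1` has not yet been measured. It differs from compound 1 in one place: pyrrolidin-3-yl in place of 6-(dimethylamino)pyridin-3-yl on a carbonyl carbon. Among the compounds with values here, no measured pair shows the same change, so the expected step, a 3.8-fold higher number from compound 1 to compound 3 (0.57 log units; beyond the scatter), is a moderate one toward weaker inhibition, with real uncertainty about its size. Compound 3 is therefore expected to give 150 nM in this assay, within a range from 40 nM to 600 nM.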

Compound 3, half-maximal inhibitory concentration in the secreted frizzled-related protein 1 assay: 40 nM
Compound 3: the middle estimate sits 3.8-fold (0.57 log units) above what was measured; the range from low to high includes it.
By their numbers in the secreted frizzled-related protein 1 assay, from the lowest: compounds 1 and 3 (each within the scatter of the next); then compound 2.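

In the secreted frizzled-related protein 1 assay, the position on the carbonyl carbon accepts a five-membered non-aromatic ring in place of the six-membered aromatic one, with no change at the digits printed from compound 1 to compound 3 (within the scatter). The aromatic ring of 6-(dimethylamino)pyridin-3-yl is therefore not required to keep this number, at least in this pair. In a physicochemical assay for solubility, at pH 7.4 (on this read-out lower numbers stand for lower solubility and higher numbers for higher solubility), compound 1 gives 6700 nM and compound 3 gives 77000 nM. Inhibition holds while the physicochemical assay moves, so the change separates the two read-outs: the measured solubility of compound 1, 6700 nM, and of compound 3, 77000 nM, an 11-fold higher number (1.06 log units; beyond the scatter)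

The compounds shown leave open how the opposite stereocentre of pyrrolidin-3-yl would read in either assay. They also leave open whether an open-chain amine or a carboxylic acid on this carbonyl carbon would preserve both results.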